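From a Pyridyl Arm to a Chlorohydroxyphenyl Arm

A few compounds are considered here, and "the series" means these few. Any claim that something is new, unique, unknown or untested is made for them only; others in the source may bear on it.

In a functional assay on K562 cells (Homo sapiens) for antiproliferative activity, read by MTT assay, with a stated time of 24 h (a higher number here means a weaker inhibitor, a lower number a stronger inhibitor), three compounds built on a shared core have been measured. Compound 1 `COc1ccc(C(=O)/C=C/c2ccc3ccccc3n2)c2c1C=CC(C)(C)O2` gives 3020 nM. Compound 3 `COc1ccc(C(=O)/C=C/c2cccc(C(F)(F)F)c2)c2c1C=CC(C)(C)O2` gives 7850 nM. Compound 2 `COc1ccc(/C=C/C(=O)c2ccc(OC)c3c2OC(C)(C)C=C3)cn1` carries a 6-methoxypyridin-3-yl on a double-bonded chain carbon bound to a double-bonded chain carbon. For compound 2 this assay records only a limit, > 10000 nM, and not a number. That limit is the limit of > 10000 nM in this assay, at which 1 of the 3 values shown sits. Compound 2 thus stands at the weak end of what has been seen, with no number to set against compound 1 or compound 3.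

Compound 4 `COc1ccc(C(=O)/C=C/c2cc(Cl)ccc2O)c2c1C=CC(C)(C)O2` is the unmeasured partner. It differs from compound 2 in a single place: 5-chloro-2-hydroxyphenyl in place of 6-methoxypyridin-3-yl on a double-bonded chain carbon bound to a double-bonded chain carbon. For the measured compounds named here, no pair of measured compounds shows this change, so the size of the step must be judged without a direct precedent. The expected step is an at least 2.0-fold lower number from compound 2 to compound 4 (0.30 log units; that floor lies within the scatter) in this assay, toward a stronger inhibitor, though a result still at the limit remains a real possibility. Compound 4 is estimated to give about 5000 nM in this assay, with a likely range from 1500 nM to 20000 nM.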

Compound 4, half-maximal inhibitory concentration: 5510 nM
Compound 4: middle estimate off by 1.1-fold (0.04 log units), on the low side; measured number inside the range.
By their numbers in this assay, from the lowest: compounds 1, 4 and 3 (each within the scatter of the next, the first and the last beyond it). At a limit, above all of these: compound 2.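

In this assay, 5-chloro-2-hydroxyphenyl on a double-bonded chain carbon bound to a double-bonded chain carbon gives compound 4 a real number, 5510 nM, and that number lies within the scatter of the numbers of both compound 1 and compound 3, so this place can hold an arm with a hydroxyl and a chlorine and still read as a number. The change from the pyridyl arm is an at least 1.8-fold lower number from compound 2 to compound 4 (0.25 log units; that floor lies within the scatter), which gives only a floor for its size and not the size itself. Compound 2 remains a limit and not a number: the limit of > 10000 nM in this assay, at which 1 of the 4 values shown sits.

Whether the chlorine or the hydroxyl accounts for the step stays open, as the two enter together in one arm, and the compounds shown cannot separate them. Also open, as far as these compounds go, is how this place would answer to a phenyl arm carrying an amine or a carboxylic acid, and whether any such arm would give a number beyond the scatter of compound 1 and compound 4.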